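Two Halogens Leave, One Bromine Enters on the Phenyl Ring

The compounds below may be only part of what the source reports. "The series", "measured", "known", "first", "only" and "open" are said of these compounds alone.

Compound 1 `NC1=NC2(CCOCC2)N(OCCCOc2ccc(F)cc2)C(N)=N1` and compound 3 `NC1=NC2(CCOCC2)N(OCCCOc2ccccc2)C(N)=N1` share a core in which an oxygen sits in the saturated ring. In an assay on isolated protein for inhibition of Dihydrofolate reductase (Homo sapiens), read by spectrophotometry, using NADPH, with stated times of 5 s and 6 min, tested at 5 uM (on this read-out higher numbers stand for a stronger effect at the one concentration tested and lower numbers for a weaker effect), compound 1 gives > 90%, which is a limit of the assay rather than a number. In this assay compound 3 likewise gives > 90%, again a limit. Within the data shown here, the single step between them, a step that the two limits leave unreadable from compound 1 to compound 3, therefore cannot be sized. Among the measured compounds shown here, compound 2 `NC1=NC2(CCSCC2)N(OCCCOc2cccc(Cl)c2Cl)C(N)=N1` carries a sulfur in the saturated ring and a 2,3-dichlorophenyl group; in this assay compound 2 gives 83.8%, the only actual number among the three values shown. The other two, those of compound 1 and compound 3, sit at a limit (the limit of > 90% in this assay, at which 2 of the 3 values shown sit).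

Compound 4 `NC1=NC2(CCSCC2)N(OCCCOc2ccccc2Br)C(N)=N1` differs from compound 2 in one place: 2-bromophenyl in place of 2,3-dichlorophenyl on an oxygen on a saturated carbon. For the measured compounds named here, no measured step bears on this change; the one step that touches the aromatic ring is unreadable because of the limit of > 90% in this assay, at which 2 of the 3 values shown sit. The expected step of a number 1.8 percentage points lower from compound 2 to compound 4 (within the scatter) is therefore small, with no direction that lies beyond the scatter, and rests on compound 2 alone with its 83.8%. Compound 4 is accordingly estimated to give 82% in this assay, within a range from 65% to 92%.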

Compound 4, a percentage reported as inhibition, at one concentration (the size of the read-out at that concentration, not a potency): 88.7%
Compound 4: the middle estimate sits 6.7 percentage points below what was measured, and the stated range covers the measured number.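

Among these compounds, the change from 2,3-dichlorophenyl to 2-bromophenyl, on an oxygen on a saturated carbon, gives the first readable step on the aromatic group in this assay: a number 4.9 percentage points higher from compound 2 to compound 4 (within the scatter). It shows that, with sulfur in the saturated ring, this read-out does not separate these two halogen-bearing phenyl groups, even though the leaving group has two chlorines and the entering group has one bromine. The only earlier step on the ring, hydrogen in place of fluoro, cannot be read because both of its values are limits, and the sulfur pair gives a comparison that the oxygen pair could not: the limit of > 90% in this assay, at which 2 of the 4 values shown sit.

The compounds shown leave open whether the exchange of sulfur for oxygen in the saturated ring changes the read-out by itself, since no pair here differs in that place alone. They also leave open how a phenyl ring bearing an amine or a carboxylic acid, or a longer chain on the oxygen, would behave in this assay, and how any of these compounds would rank in a full measure of potency rather than at one concentration.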